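The compounds below may be only part of what the source reports. "The series", "measured", "known", "first", "only" and "open" are said of these compounds alone.

Three analogues of a shared core have been measured in a functional assay on A549 cells (Homo sapiens) for inhibition, read by sulforhodamine B assay, with a stated time of 72 h; a lower number here means a stronger inhibitor, a higher number a weaker inhibitor. Compound 1 `CC1CN(C(=O)c2c(N)sc(-c3ccc(Cl)cc3)c2-c2ccc(Cl)cc2)CCN1` gives 4930 nM. Compound 2 `Nc1sc(-c2ccc(Cl)cc2)c(-c2ccc(Cl)cc2)c1C(=O)Nc1ccccc1` gives 25000 nM, the second highest of the three numbers: its nearest neighbour is compound 3 `CCOC(=O)Nc1sc(-c2ccc(Cl)cc2)c(-c2ccc(Cl)cc2)c1C(=O)NC1CC1`, which gives 39800 nM, within the scatter of compound 2, while compound 1 lies beyond the scatter below it. Going by the values given here, the one step measured in one place is a 5.1-fold higher number from compound 1 to compound 2 (0.71 log units; beyond the scatter), a modest shift. Compound 3 differs from compound 2 in two places, so its value alone is known.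

Compound 4 `Nc1sc(-c2ccc(Cl)cc2)c(-c2ccc(Cl)cc2)c1C(=O)NC1CCCC1` differs from compound 2 in that (cyclopentyl in place of phenyl on an amide-type nitrogen). Among the compounds with values here, the step from compound 1 to compound 2 concerns the same amide-type nitrogen, but no measured pair exchanges phenyl for a saturated ring there, so the direction is open. She expects a change no larger than that modest step, and most likely within the scatter: a 1.3-fold lower number from compound 2 to compound 4 (0.10 log units; within the scatter). She therefore estimates compound 4 at 20000 nM, between 6000 nM and 60000 nM.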

Compound 4, half-maximal inhibitory concentration: 6790 nM
Compound 4: the middle estimate sits 2.9-fold (0.47 log units) above what was measured; low and high end bracket the measured number.
By their numbers in this assay, from the lowest: compounds 1 and 4 (each within the scatter of the next); then compounds 2 and 3 (each within the scatter of the next).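

In this assay, going by these compounds alone, the saturated ring on the amide-type nitrogen departs measurably from the aromatic one, with a 3.7-fold lower number from compound 2 to compound 4 (0.57 log units; beyond the scatter) as cyclopentyl takes the place of phenyl, a exchange no earlier pair had covered. With a 1.4-fold higher number from compound 1 to compound 4 (0.14 log units; within the scatter) the two compounds cannot be told apart, so at this level of activity a ring of carbon only does as well as the 3-methylpiperazin-1-yl group on the carbonyl carbon, and the ring nitrogens of that group are not required. No measurement at hand speaks to the reason for either result.

Going by these compounds, it remains open whether a cyclohexyl ring or an open butyl chain on the same nitrogen would behave as cyclopentyl does. Equally open, on these data alone, is whether a hydroxyl or a carboxylic acid on the cyclopentyl ring would be tolerated.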